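The compounds below may be only part of what the source reports. "The series", "measured", "known", "first", "only" and "open" are said of these compounds alone.

Measured compounds in an ADME assay on L6 cells (Rattus norvegicus) for cytotoxicity, read by resazurin assay, with a stated time of 72 h; on this read-out lower numbers stand for stronger inhibition and higher numbers for weaker inhibition:
- compound 1 `O=C(CN1CCCC1)OC1CC2(N3CCCCC3)CC(c3ccccc3)C1C(c1ccccc1)C2`: 16400 nM
- compound 2 `CN1CCN(CC(=O)OC2CC3(N(C)C)CC(c4ccccc4)C2C(c2ccccc2)C3)CC1`: 39900 nM
- compound 3 `CN1CCN(CC(=O)OC2CC3(N4CCCC4)CC(c4ccccc4)C2C(c2ccccc2)C3)CC1`: 24600 nM

Compound 2 stands highest of the three numbers in this assay. Its nearest neighbour is compound 3, reached by a 1.6-fold lower number from compound 2 to compound 3 (0.21 log units; within the scatter), a step that stays within the scatter; the furthest is compound 1, whose number lies beyond the scatter from that of compound 2.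

The next compound, compound 4 `CN1CCN(CC(=O)NC2CC3(N(C)C)CC(c4ccccc4)C2C(c2ccccc2)C3)CC1`, is not yet measured in this assay. It differs from compound 2 in one place: (((4-methylpiperazin-1-yl)methyl)carbonyl)amino in place of (((4-methylpiperazin-1-yl)methyl)carbonyl)oxy on a saturated ring carbon

Within the data shown here, no measured step bears on this change. Among the measured compounds shown here, the single step recorded so far, a 1.6-fold lower number from compound 2 to compound 3 (0.21 log units; within the scatter), concerns the group on a different saturated ring carbon and leaves the (((4-methylpiperazin-1-yl)methyl)carbonyl)oxy group untouched, so it gives no guidance on exchanging that group for (((4-methylpiperazin-1-yl)methyl)carbonyl)amino. With nothing to build on, the expectation for compound 4 in this assay is a step of no size beyond the scatter, in either direction, from compound 2, which is what a 1.0-fold higher number from compound 2 to compound 4 (0.00 log units; within the scatter) expresses. On that basis compound 4 is estimated at 40000 nM in this assay, with a range from 15000 nM to 100000 nM that reflects the absence of any comparable step in the series.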

Compound 4, half-maximal inhibitory concentration: 66200 nM
Compound 4: middle estimate off by 1.7-fold (0.22 log units), on the low side, within the range that was stated.
By their numbers in this assay, from the lowest: compounds 1, 3, 2 and 4 (each within the scatter of the next, the first and the last beyond it).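

In this assay, among these compounds, this is the first reading at the saturated ring carbon next to the ring atom that bears a fused ring, and it gives a 1.7-fold higher number from compound 2 to compound 4 (0.22 log units; within the scatter) for (((4-methylpiperazin-1-yl)methyl)carbonyl)amino in place of (((4-methylpiperazin-1-yl)methyl)carbonyl)oxy. On this single pair, the amide and ester links cannot be told apart in this read-out, even though the entering group swaps an oxygen for a nitrogen and carries a hydrogen-bond donor that the leaving group lacks. No accompanying measurement bears on the origin of this step.

From the compounds shown here alone, it remains open whether the same exchange would also stay within the scatter with pyrrolidin-1-yl or piperidin-1-yl on the ring carbon that bears dimethylamino in compound 4, since this single pair covers only the dimethylamino case. Also unresolved is how a simple primary amine in place of the whole group, or a longer chain carrying the 4-methylpiperazin-1-yl ring, would read at this position.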